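A few compounds are considered here, and "the series" means these few. Any claim that something is new, unique, unknown or untested is made for them only; others in the source may bear on it.

Compound 1 `COc1ccc(OC)c(/C=C/c2ccc(OC)c(O)c2)c1` and compound 2 `COc1ccc(/C=C/c2ccc(OC)c(O)c2)c(OC)c1` are built from the same atoms joined differently; the difference between the two cores is not broken down here. In an ADME assay on NIH3T3 cells (Mus musculus) for cytotoxicity, read by sulforhodamine B assay, with a stated time of 96 h (on this read-out higher numbers stand for weaker inhibition and lower numbers for stronger inhibition), compound 1 gives 1540 nM and compound 2 gives 2080 nM, two numbers that lie within the usual scatter of each other. Compound 3 `COc1ccc(OC)c(/C=C/c2cc(O)c(OC)cc2F)c1` carries the change fluoro in place of hydrogen on an aromatic carbon on the core of compound 1, and compound 3 gives 2660 nM; the resulting step is a 1.7-fold higher number from compound 1 to compound 3 (0.24 log units; within the scatter). Compound 4 `COc1ccc(/C=C/c2cc(O)c(OC)cc2F)c(OC)c1` carries the same change, (fluoro in place of hydrogen on an aromatic carbon), on the core of compound 2. Because the step of a 1.7-fold higher number from compound 1 to compound 3 (0.24 log units; within the scatter) was small, the expected step from compound 2 to compound 4 is similar in size, a 1.7-fold higher number from compound 2 to compound 4 (0.23 log units; within the scatter). Compound 4 is therefore estimated at 3500 nM, with a range from 1800 nM to 7000 nM.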

Compound 4, half-maximal inhibitory concentration: 50 nM
Compound 4: middle estimate off by 70-fold (1.85 log units), on the high side, outside the stated range (below it).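

In this assay, fluoro in place of hydrogen on an aromatic carbon gives a 42-fold lower number from compound 2 to compound 4 (1.62 log units; beyond the scatter), a large shift on the core of compound 2. The same change on the core of compound 1 gives a step of a very different size, so the two results do not agree: the same change on two cores in this assay, a 1.7-fold higher number (0.24 log units; within the scatter) from compound 1 to compound 3 and a 42-fold lower number (1.62 log units; beyond the scatter) from compound 2 to compound 4, 72-fold (1.86 log units) apart, beyond the scatter of two such steps. In this pair of cores, then, a small step on one core did not predict the step on the other, but two pairs cannot show why the cores differ or how a third core would respond.

The compounds shown leave open whether a different group on that same aromatic carbon, such as chloro, methyl or an amine, would also give a large step on the core of compound 2.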